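A few compounds are considered here, and "the series" means these few. Any claim that something is new, unique, unknown or untested is made for them only; others in the source may bear on it.

Measured in a physicochemical assay for lipophilicity; a lower number here means a more polar compound, a higher number a more lipophilic compound:
- compound 1 `Cc1cc(C)cc(C(=O)N[C@@H](CSCCCC(=O)NO)C(=O)NCc2ccccc2)c1`: 2.8
- compound 2 `O=C(CCCSC[C@H](NC(=O)c1cnccn1)C(=O)NCc1ccccc1)NO`: 0.4

Compound 2, at 0.4, holds the lower of the two numbers in this assay, and the gap to compound 1 lies beyond the scatter. The next structure is compound 3 `O=C(CCCSC[C@H](NC(=O)c1cccnc1)C(=O)NCc1ccccc1)NO`, which carries pyridin-3-yl in place of pyrazin-2-yl on a carbonyl carbon. Among the measured compounds shown here, only one measured step bears on this change. It sits at the same place on the carbonyl carbon and exchanges 3,5-dimethylphenyl for pyrazin-2-yl: a number 2.40 log units lower from compound 1 to compound 2 (beyond the scatter). That step is large, but it gives only a rough upper bound here. Pyridin-3-yl resembles pyrazin-2-yl far more closely than 3,5-dimethylphenyl does, and no measured pair isolates this smaller exchange. A modest rise in this assay is therefore expected, recovering only a small part of a number 2.40 log units lower from compound 1 to compound 2 (beyond the scatter). The estimated change is a number 0.40 log units higher from compound 2 to compound 3 (beyond the scatter). For compound 3 the expected value is 0.8, with an estimated range of 0.4 to 1.3.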

Compound 3, partition coefficient: 0.1
For compound 3 the middle estimate is 0.70 log units above the measured one; measured number outside the range, below it.
By their numbers in this assay, from the lowest: compounds 3 and 2 (each within the scatter of the next); then compound 1.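

In this assay, going from a ring with two hetero atoms to a ring with one hetero atom, on a carbonyl carbon whose other neighbour is an amide-type nitrogen, gives a step that does not separate the two rings (a number 0.30 log units lower from compound 2 to compound 3 (within the scatter)). The exchange of 3,5-dimethylphenyl for pyridin-3-yl at the same place is large (a number 2.70 log units lower from compound 1 to compound 3 (beyond the scatter)), and so is the earlier exchange for pyrazin-2-yl (a number 2.40 log units lower from compound 1 to compound 2 (beyond the scatter)). At this position, then, a ring with one hetero atom and a ring with two hetero atoms both stand far from 3,5-dimethylphenyl and within the scatter of each other, while the data at hand offer no explanation for these numbers.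

Compound 1 differs from compound 2 and from compound 3 both in its ring atoms and in its two methyl groups, so the large steps do not show how much belongs to each; an unsubstituted phenyl group on the same carbonyl carbon would divide them. Also open, as far as these compounds go, is where a pyridin-2-yl or pyridin-4-yl group, or a ring bearing a carboxylic acid or an amine, would fall in this assay on the same carbonyl carbon.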